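The compounds below may be only part of what the source reports. "The series", "measured", "known", "first", "only" and "open" are said of these compounds alone.

Compound 1 `CCCCc1nc(=O)c(S(=O)(=O)c2ccc(-c3ccnc(NC(=O)C4CC4)c3)cc2)c(O)n1-c1c(OC)cccc1OC` gives 84% in an ADME assay on microsomes from liver (Homo sapiens) for metabolic stability, using NADPH, with a stated time of 10 min; on this read-out higher numbers stand for a more stable compound and lower numbers for a less stable compound. Compound 2 `CCCCc1[nH]c(=O)c(S(=O)(=O)c2ccc(-c3ccc(F)cc3)cc2)c(O)c1-c1c(OC)cccc1OC` gives "not determined" (no result reported) in this assay.

Going by the values given here, compound 2 therefore stands nowhere on the numbers: no value for this assay, so no step from compound 2 can be sized or given a direction. Compound 3 `CCCCc1[nH]c(=O)c(S(=O)(=O)c2ccc(-n3ccccc3=O)cc2)c(O)c1-c1c(OC)cccc1OC` differs from compound 2 in one place: a group of 7 heavy atoms (5 carbon, 1 nitrogen, 1 oxygen; one six-membered aromatic ring with 1 hetero atom) in place of a group of 7 heavy atoms (6 carbon, 1 fluorine; one six-membered aromatic ring of carbon only), on an aromatic carbon. Among the compounds with values here, with no measured step for this change, the only anchor is the value of compound 1, 84%, in a related but not single-change structure. Compound 3 is expected near 75% in this assay, with a range of 45% to 95%, the wide range reflecting the absence of a number for compound 2.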

Compound 3, percent of the compound remaining: 100%
Compound 3: middle estimate off by 25 percentage points, on the low side; the whole stated range lies below it.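

No step can be read from compound 2 to compound 3 in this assay: compound 2 carries no number there. From the compounds shown here alone, what replacing the 4-fluorophenyl group does to this read-out stays open. Nothing at hand bears on the result.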